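The source may report more compounds than this note shows. Statements on the series, on what has been measured and on what is new or still open speak of the compounds shown alone.

In a functional assay on HepG2 cells (Homo sapiens) for antiproliferative activity, read by CCK-8 assay, with a stated time of 48 h (a lower number here means a stronger inhibitor, a higher number a weaker inhibitor), three compounds with a shared core have been measured. Compound 1 `COc1ccc(/C=C\c2cc(OC)c(OC)c(OC)c2)cc1OCc1ccc(CN2CCCCC2C(=O)O)cc1` gives 3100 nM. Compound 2 `COc1ccc(/C=C\c2cc(OC)c(OC)c(OC)c2)cc1OCc1ccc(CN[C@H](C(=O)O)[C@H](C)O)cc1` gives > 10000 nM, which is a limit of the assay and not a number. Compound 3 `COc1ccc(/C=C\c2cc(OC)c(OC)c(OC)c2)cc1OCc1ccc(CN2CC(C(=O)O)C2)cc1` gives > 10000 nM, again a limit, so its place is known only as the limit of > 10000 nM in this assay, at which 2 of the 3 values shown sit.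

The next change is 2-((2-aminoethyl)carbamoyl)piperidin-1-yl in place of 3-carboxyazetidin-1-yl on a saturated chain carbon bound to an aromatic carbon, giving compound 4 `COc1ccc(/C=C\c2cc(OC)c(OC)c(OC)c2)cc1OCc1ccc(CN2CCCCC2C(=O)NCCN)cc1`: 2-((2-aminoethyl)carbamoyl)piperidin-1-yl in place of 3-carboxyazetidin-1-yl on a saturated chain carbon bound to an aromatic carbon. The closest guide is an at least 3.2-fold higher number from compound 1 to compound 3 (0.50 log units; beyond the scatter), where 3-carboxyazetidin-1-yl replaced 2-carboxypiperidin-1-yl. A similar loss appears in an at least 3.2-fold higher number from compound 1 to compound 2 (0.50 log units; beyond the scatter), while a step that the two limits leave unreadable from compound 2 to compound 3 offers no help. Compound 4 regains the six-membered non-aromatic ring with 1 hetero atom carried by compound 1, which gives 3100 nM. Going by the values given here, no measured compound tests the 2-aminoethyl part of the new group, so the range must stay wide.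

A lower number is therefore expected in this assay, an estimated at least 4.0-fold lower number from compound 3 to compound 4 (0.60 log units; beyond the scatter). For compound 4, the estimated value is 2500 nM, with an expected range from 600 nM to 10000 nM.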

Compound 4, half-maximal inhibitory concentration: 4800 nM
The estimate for compound 4 lay 1.9-fold (0.28 log units) below the measured number; the range from low to high includes it.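

In this assay, this position accepts an amide in place of the carboxylic acid of compound 1: a 1.5-fold higher number from compound 1 to compound 4 (0.19 log units; within the scatter), so the two compounds cannot be told apart. Compound 4 also has a readable value, unlike the two compounds without a six-membered non-aromatic ring, giving an at least 2.0-fold lower number from compound 3 to compound 4 (0.31 log units; beyond the scatter) and an at least 2.0-fold lower number from compound 2 to compound 4 (0.31 log units; beyond the scatter). Those two compounds, 2 and 3, sit at a limit of the assay and not at a number: the limit of > 10000 nM in this assay, at which 2 of the 4 values shown sit.

The step between compound 2 and compound 3 cannot be read, as both values are limits. As far as these compounds go, what the amine at the end of the 2-aminoethyl chain contributes remains open, and a methyl amide or a 3-aminopropyl amide on the same ring would be needed to test it.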